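The compounds below may be only part of what the source reports. "The series", "measured", "known", "first", "only" and "open" are said of these compounds alone.

Measured so far in an assay on isolated protein for inhibition of Gonadotropin-releasing hormone receptor (Homo sapiens); a higher number here means a weaker inhibitor, a lower number a stronger inhibitor:
compound 1 `COc1ccc([N+](=O)[O-])cc1CSc1nc2cc(NC(=O)OC(C)(C)C)ccc2n1C(C)C` gives 880 nM
compound 2 `COc1ccc([N+](=O)[O-])cc1CSc1nc2cc(NC(=O)C3CCC3)ccc2n1C(C)C` gives 1500 nM
compound 3 `COc1ccc([N+](=O)[O-])cc1CSc1nc2cc(NC(=O)NC(C)(C)C)ccc2n1C(C)C` gives 62 nM

All three share one core and differ only in the group attached to the carbonyl carbon of the side chain. Compound 3 has the lowest number of the three: the step of a 14-fold lower number from compound 1 to compound 3 (1.15 log units; beyond the scatter) is large, and so is the step of a 24-fold lower number from compound 2 to compound 3 (1.38 log units; beyond the scatter), both well beyond the scatter, whereas the step of a 1.7-fold higher number from compound 1 to compound 2 (0.23 log units; within the scatter) is within it. Compound 3 is therefore the strongest inhibitor among the compounds measured here.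

Compound 4 `COc1ccc([N+](=O)[O-])cc1CSc1nc2cc(NC(=O)NC(C)C)ccc2n1C(C)C` keeps the urea of compound 3 and differs from it by a single small change: hydrogen in place of methyl on a saturated chain carbon bound to an amide-type nitrogen and two saturated chain carbons. For the measured compounds named here, none of the measured steps bears directly on this change; each of them exchanges the whole group on the carbonyl carbon, and none trims a methyl from a branched chain. What the data do show is that the urea, not the finer shape of the chain, sets compound 3 apart from compound 1 and compound 2. A trimmed urea is thus expected to keep most of that gain, with at most a modest rise in number. The step expected is a 1.8-fold higher number from compound 3 to compound 4 (0.25 log units; within the scatter). Compound 4 is expected to give about 110 nM, within a range from 40 nM to 320 nM.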

Compound 4, half-maximal inhibitory concentration: 600 nM
For compound 4 the middle estimate is 5.5-fold (0.74 log units) below the measured one, and the stated range ends below it.
By their numbers in this assay, from the lowest: compound 3; then compounds 4, 1 and 2 (each within the scatter of the next, the first and the last beyond it).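

In this assay, for the compounds shown here, trimming a single methyl from the tert-butyl group to leave isopropyl has a much larger effect than the earlier comparisons could reveal (a 9.7-fold higher number from compound 3 to compound 4 (0.99 log units; beyond the scatter)), so the urea alone does not secure the low number of compound 3, and the exact group on its amide-type nitrogen matters as well. The urea with isopropyl cannot be told apart from the compound with tert-butoxy on the carbonyl carbon (a 1.5-fold lower number from compound 1 to compound 4 (0.17 log units; within the scatter)), and it keeps only a modest edge over the compound with cyclobutyl there (a 2.5-fold lower number from compound 2 to compound 4 (0.40 log units; beyond the scatter)). Nothing available here accounts for why one methyl makes this difference.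

The compounds shown leave open how the number responds to other groups on that amide-type nitrogen, such as cyclobutyl, cyclopentyl or a longer chain like n-butyl, so it remains unknown whether tert-butyl is uniquely favoured. Also open, going by these compounds, is what happens when the chain is trimmed further, to ethyl or methyl.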